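This account rests on a few compounds, and the source may have more. Where it says the series, first, only, none or still open, it means among the compounds named here.

Compound 1 `O=C(O)/C(F)=C/c1ccc(O)c(O)c1`: -5.8%
Compound 2 `O=C(O)/C(F)=C/c1ccccc1`: 34%
Compound 3 `N#C/C(=C\c1ccsc1)C(=O)O`: 1.8%

All three were tested in a functional assay on the whole organism (strain CD1) for inhibition, with Mus musculus as the target, with stated times of 15 min and 20 min, at a dose of 10 mg/kg by the subcutaneous route; on this read-out lower numbers stand for less inhibition and higher numbers for more inhibition at the one dose given (going by the name of the read-out). Compound 3 gives 1.8%, the second highest of the three numbers. Its nearest neighbour is compound 1, whose -5.8% lies within the usual scatter of it, so the two cannot be told apart. Compound 2, with 34%, stands beyond the scatter above compound 3. Compound 4 `NC/C(=C\c1ccsc1)C(=O)O` has not yet been measured. It differs from compound 3 in one place: aminomethyl in place of cyano on a double-bonded chain carbon bound to a carbonyl carbon and a double-bonded chain carbon. Going by the values given here, no measured pair shows this change, so there is nothing here to tell how large its effect might be. The step is expected to be small, a number 3.2 percentage points higher from compound 3 to compound 4 (within the scatter), not clearly beyond the scatter. Compound 4 is therefore expected to give about 5% in this assay, between -15% and 30%.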

Compound 4, a percentage reported as inhibition, in the whole organism at one dose (the size of the read-out at that dose, not a potency): -13.5%
Compound 4: the middle estimate sits 18.5 percentage points above what was measured; measured number inside the range.
By their numbers in this assay, from the lowest: compounds 4, 1 and 3 (each within the scatter of the next, the first and the last beyond it); then compound 2.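

Going by these compounds alone, replacing cyano with aminomethyl on this double-bonded chain carbon is the first single change that can be read in this assay, and it gives a number 15.3 percentage points lower from compound 3 to compound 4 (beyond the scatter), so what sits at this position can shift the result by a modest amount. The two groups have the same number of heavy atoms, yet aminomethyl adds a hydrogen-bond donor and removes the triple bond. Nothing available explains the step.

Going by these compounds, whether a hydroxymethyl group, a carboxylic acid or a longer amine chain at this position would give a higher or lower number remains open.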